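The source may report more compounds than this note shows. Statements on the series, on what has been measured and on what is new or still open speak of the compounds shown alone.

Measured compounds:
Compound 1 `Cc1ccc(N2N=C(C(C)(C)C)CC2c2ccc(O)cc2)c(C)c1` gives 59.9% in an assay on isolated protein for inhibition of protein kinase C zeta type (Homo sapiens), with a stated time of 4 min, tested at 62.5 uM; on this read-out higher numbers stand for more inhibition at the one concentration tested (going by the name of the read-out) and lower numbers for less inhibition.
Compound 2 `CC(C)(C)C1=NN(c2c(Cl)cccc2Cl)C(c2ccc(O)cc2)C1` gives 65.5% in this assay.

Compound 2 stands at the higher of the two numbers, but the step of a number 5.6 percentage points higher from compound 1 to compound 2 (within the scatter) is within the scatter, so compound 1 cannot be told apart from it. Compound 3 `CC(C)(C)C1=NN(c2ccc(O)cc2)C(c2ccc(O)cc2)C1` has not yet been measured. It differs from compound 2 by 4-hydroxyphenyl in place of 2,6-dichlorophenyl on an amine nitrogen in a ring. Within the data shown here, the only measured step that bears on this, a number 5.6 percentage points higher from compound 1 to compound 2 (within the scatter), also exchanged the aryl group on the ring nitrogen and stayed within the scatter; yet it swapped one substituted phenyl for another of similar kind, whereas here 4-hydroxyphenyl enters, so that step is only a partial guide. With nothing more to go on, a step of about a number 5.5 percentage points lower from compound 2 to compound 3 (within the scatter) is expected, that is, none beyond the scatter, with a broad range. The estimate for compound 3 in this assay is therefore 60%, between 40% and 80%.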

Compound 3, a percentage reported as inhibition, at one concentration (the size of the read-out at that concentration, not a potency): 40.9%
Compound 3: the middle estimate sits 19.1 percentage points above what was measured; the measured number falls inside the stated range.
By their numbers in this assay, from the lowest: compound 3; then compounds 1 and 2 (each within the scatter of the next).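

The aryl group on an amine nitrogen in a ring proves able to shift the number in this assay: putting 4-hydroxyphenyl there gives a number 24.6 percentage points lower from compound 2 to compound 3 (beyond the scatter) and a number 19 percentage points lower from compound 1 to compound 3 (beyond the scatter), whereas the earlier exchange between 2,4-dimethylphenyl and 2,6-dichlorophenyl stayed within the scatter. Among these compounds, the position therefore does not treat all aryl groups alike, and among the three compounds the lower number goes with the one group that carries a hydrogen-bond donor and acceptor. Nothing available here accounts for this drop.

The compounds shown leave open whether the hydroxyl group itself goes with the lower number, as no methoxy or amine group on that phenyl ring appears among them, nor a plain phenyl. They also leave open how the tert-butyl group and the 4-hydroxyphenyl group on the other ring atom contribute, as both stay the same throughout.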